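Urea versus carbonyl link on the pyrazole series

A few compounds are considered here, and "the series" means these few. Any claim that something is new, unique, unknown or untested is made for them only; others in the source may bear on it.

Measured so far:
compound 1 `O=C(Nc1cccc(-n2cc(-c3ccncc3)c(-c3ccc(Cl)c(O)c3)n2)c1)Nc1cccc(C(F)(F)F)c1`: > 32500 nM
compound 2 `COc1cc(-c2nn(-c3cccc(NC(=O)Nc4cc(C(F)(F)F)cc(C(F)(F)F)c4)c3)cc2-c2ccncc2)ccc1Cl`: 4870 nM
compound 3 `COc1cc(-c2nn(-c3cccc(NC(=O)c4cccc(C(F)(F)F)c4)c3)cc2-c2ccncc2)ccc1Cl`: > 50000 nM

In a functional assay on SW-620 cells (Homo sapiens) for inhibition, read by sulforhodamine B assay, with a stated time of 48 h (on this read-out higher numbers stand for lower toxicity in this test and lower numbers for higher toxicity in this test), compound 3 gives only a limit, > 50000 nM, so no number stands for it; this is the limit of > 50000 nM in this assay, at which 1 of the 3 values shown sits. Of the three values shown, one further is a limit as well: compound 1 gives > 32500 nM in this assay, which is the limit of > 32500 nM in this assay, at which 1 of the 3 values shown sits. The one measured number belongs to compound 2, at 4870 nM in this assay, so compound 3 sits at the weaker end of what is shown, but its distance from compound 2 cannot be given.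

Compound 4 `COc1cc(-c2nn(-c3cccc(NC(=O)Nc4ccc(Cl)c(Cl)c4)c3)cc2-c2ccncc2)ccc1Cl` differs from compound 3 in one place: (3,4-dichlorophenyl)amino in place of 3-(trifluoromethyl)phenyl on a carbonyl carbon. Read one bond further out, the change is (3-(trifluoromethyl)phenyl)carbonyl to (3,4-dichlorophenyl)carbamoyl, which brings compound 4 closer to compound 2 in its link to the core. Within the data shown here, no measured step covers this change. On that basis the step is expected to go toward higher toxicity, beyond the scatter, with compound 2 and its 4870 nM as the nearer anchor; the estimate for compound 4 is 9000 nM with a range from 3000 nM to 40000 nM, an expected step of an at least 5.5-fold lower number from compound 3 to compound 4 (0.74 log units; beyond the scatter).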

Compound 4, concentration lethal to 50% of the cells: > 50000 nM
Compound 4: a limit, no number; the forecaster's own chance of this, stated with the estimate: 25%; middle value at least 5.5-fold (0.74 log units) from the limit.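

Compound 3 and compound 4 both stand as limits in this assay, so no step can be read between them: the limit of > 50000 nM in this assay, at which 2 of the 4 values shown sit.

The compounds shown leave open whether (3,4-dichlorophenyl)amino in place of 3-(trifluoromethyl)phenyl on a carbonyl carbon changes this read-out at all.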